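The source may report more compounds than this note shows. Statements on the series, on what has been measured and on what is new or still open speak of the compounds shown alone.

Measured so far:
compound 1 `COc1cc(C(=O)N/N=C/c2ccccc2C(F)(F)F)cc(OC)c1OC` gives 22.1%
compound 2 `COc1cc(C(=O)N/N=C/c2ccccc2F)cc(OC)c1OC` gives 51.6%
compound 3 `COc1cc(C2=NN(C(C)=O)C(c3ccccc3C(F)(F)F)O2)cc(OC)c1OC` gives 31.8%

In a functional assay on BGC-823 cells (Homo sapiens) for antiproliferative activity, read by MTT assay, tested at 1 uM (on this read-out lower numbers stand for a weaker effect and higher numbers for a stronger effect at the one concentration tested), compound 2 stands highest of the three numbers; compound 3 is nearest and compound 1 furthest, both gaps beyond the scatter. Going by the values given here, the one step between compounds that differ in a single place is a number 29.5 percentage points higher from compound 1 to compound 2 (beyond the scatter), a modest rise. Compound 3 carries a different core and is set against the others only by its value.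

Compound 4 `COc1cc(C(=O)N/N=C/c2cccc(F)c2)cc(OC)c1OC` is not yet measured. It differs from compound 2 as follows: 3-fluorophenyl in place of 2-fluorophenyl on a carbon with a double bond to nitrogen. This is a change in where the fluorine sits on the ring, not an exchange of one group for another, so the measured step from compound 1 to compound 2 does not speak to it; it only shows that this assay is sensitive to the substituent on that ring. Among the compounds with values here, no measured pair shows the effect of moving a fluorine from one ring position to another, and the series offers no basis for expecting a step beyond the scatter in either direction.

The expected step is therefore a number 5.6 percentage points lower from compound 2 to compound 4 (within the scatter), inside the usual scatter but with wide uncertainty. Compound 4 is estimated to give 46%, in the range 24% to 66%.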

Compound 4, a percentage reported as inhibition, at one concentration (the size of the read-out at that concentration, not a potency): 13.6%
Compound 4: middle estimate off by 32.4 percentage points, on the high side, outside the stated range (below it).
By their numbers in this assay, from the lowest: compounds 4, 1 and 3 (each within the scatter of the next, the first and the last beyond it); then compound 2.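

In this assay, 2-fluorophenyl and 3-fluorophenyl have the same atoms and the same counts, yet the exchange gives a number 38 percentage points lower from compound 2 to compound 4 (beyond the scatter), a large step. The earlier step, a number 29.5 percentage points higher from compound 1 to compound 2 (beyond the scatter), showed only that the read-out responds to a change of group on this ring; the new pair shows that it also responds to where a single fluorine sits, with the group itself unchanged, so the 2-fluorophenyl of compound 2 cannot be taken as standing for fluorophenyl groups in general. No available evidence accounts for the size of this step or says what lies behind it.

The compounds shown leave open whether the same dependence on ring position holds for other groups, such as chloro, nitrile or an amine, and whether trifluoromethyl would respond as fluoro does. They also leave open whether the difference between 2-fluorophenyl and 3-fluorophenyl carries over to the core of compound 3, and, with a single concentration as the read-out, how it would appear in a full measure of potency.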